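The compounds below may be only part of what the source reports. "The series", "measured", "known", "first", "only" and "open" are said of these compounds alone.

Three compounds built on a shared core are in view. In an in vitro functional assay on CHO-CREluc cells for antagonist activity at growth hormone secretagogue receptor type 1 (Homo sapiens), read by a luciferase reporter, with a stated time of 4 h (on this read-out lower numbers stand for stronger inhibition and higher numbers for weaker inhibition), compound 1 `Cc1cc2c(cc1Cl)NC(=O)C2(NC(=O)CN1CCN(c2ccncc2)CC1)c1ccc(Cl)cc1` reaches only the assay limit, > 10000 nM, so no number is attached to it. Compound 1 thus sits at the limit of > 10000 nM in this assay, at which 1 of the 2 values shown sits. Within the data shown here, compound 2 `COc1ccc(C2(NC(=O)CN3CCN(C)CC3)C(=O)Nc3cc(Cl)c(C)cc32)cc1` gives 525 nM in this assay, and this is the only measured number in the set. Compound 3 `Cc1cc2c(cc1Cl)NC(=O)C2(NC(=O)CN1CCN(C)CC1)c1ccccc1Cl` has not yet been measured. It differs from compound 2 in one place: 2-chlorophenyl in place of 4-methoxyphenyl on a saturated ring carbon. Among the measured compounds shown here, no measured pair shows what this change does, so its direction is open. The change is expected to give a 1.1-fold higher number from compound 2 to compound 3 (0.06 log units; within the scatter), close to the ordinary scatter. Compound 3 is therefore estimated at 600 nM, with a plausible range from 150 nM to 3000 nM.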

Compound 3, half-maximal inhibitory concentration: > 10000 nM
Compound 3: only a limit was reported; the forecaster's own chance of this, stated with the estimate: 15%; middle value at least 16-fold (1.22 log units) from the limit.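

In this assay, the group on the saturated ring carbon proves decisive: 2-chlorophenyl in place of 4-methoxyphenyl gives an at least 19-fold higher number from compound 2 to compound 3 (1.27 log units; beyond the scatter). Among these compounds, this is the first pair in the set that differs only at this position, and it shows that this one change is enough to turn a compound with a measured number into one without. Compound 3 reaches only a limit, so the true size of the step remains unknown, and compound 1 carries the same limit: the limit of > 10000 nM in this assay, at which 2 of the 3 values shown sit.

The compounds shown cannot separate the effect of losing the methoxy group from that of adding chlorine, since both happen in the same step. A plain phenyl or a 2-methoxyphenyl group on this carbon would help to pull those two parts apart.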